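Chlorophenyl Analogues of a Weak Antiproliferative Hit

The compounds below may be only part of what the source reports. "The series", "measured", "known", "first", "only" and "open" are said of these compounds alone.

Compound 1 `Fc1ccccc1N1CCN(Cn2nc(-c3ccc4c(c3)OCCO4)oc2=S)CC1`: 37300 nM
Compound 2 `S=c1oc(-c2ccc3c(c2)OCCO3)nn1CN1CCN(c2ccc(Cl)cc2)CC1`: > 50000 nM

Among the compounds with values here, in a functional assay on HeLa cells (Homo sapiens) for antiproliferative activity, read by MTT assay, with a stated time of 48 h (a lower number here means a stronger inhibitor, a higher number a weaker inhibitor), compound 1 gives 37300 nM, the only number in this set. Compound 2 reaches only a limit of the assay, > 50000 nM. The step of an at least 1.3-fold higher number from compound 1 to compound 2 (0.12 log units; that floor lies within the scatter) points toward weaker activity, but its floor lies within the scatter. Compound 3 `S=c1oc(-c2ccc3c(c2)OCCO3)nn1CN1CCN(c2cccc(Cl)c2)CC1` differs from compound 1 by 3-chlorophenyl in place of 2-fluorophenyl on an amine nitrogen in a ring. Within the data shown here, the one measured step that bears on it is an at least 1.3-fold higher number from compound 1 to compound 2 (0.12 log units; that floor lies within the scatter), capped by the limit of > 50000 nM in this assay, at which 1 of the 2 values shown sits. A small step toward a higher number or none beyond the scatter is therefore expected, as a 1.2-fold higher number from compound 1 to compound 3 (0.08 log units; within the scatter). Compound 3 is estimated at 45000 nM, between 20000 nM and 100000 nM.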

Compound 3, half-maximal inhibitory concentration: 47200 nM
Compound 3: the middle estimate sits 1.0-fold (0.02 log units) below what was measured, within the range that was stated.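

Within the data shown here, the step of a 1.3-fold higher number from compound 1 to compound 3 (0.10 log units; within the scatter) gives the first measured number for a chlorophenyl group at this place: in this assay, 3-chlorophenyl in place of 2-fluorophenyl on the amine nitrogen in a ring brings no change beyond the scatter. The step of an at least 1.0-fold lower number from compound 2 to compound 3 (0.02 log units; that floor lies within the scatter) cannot separate the two chlorophenyl groups, because one of them is known only as a limit: the limit of > 50000 nM in this assay, at which 1 of the 3 values shown sits.

As far as these compounds go, whether a benzyl or an acetyl group on this nitrogen would shift the number beyond the scatter stays open. So does the effect of any change to the shared core.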